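This account rests on a few compounds, and the source may have more. Where it says the series, first, only, none or still open, it means among the compounds named here.

Measured so far in an assay on isolated protein for inhibition of N-acylethanolamine-hydrolyzing acid amidase (Homo sapiens), read by fluorescence, with a stated time of 90 min; a lower number here means a stronger inhibitor, a higher number a weaker inhibitor:
compound 1 `Fc1cc(-c2ccc3c(c2)CCO3)ccc1CO[C@H]1C[C@@H](N=C=S)C1` gives 4.5 nM;
compound 2 `COc1ccc(-c2ccc(CO[C@H]3C[C@@H](N=C=S)C3)nc2)cc1F` gives 20 nM;
compound 3 `CC(C)c1ccc(-c2ccc(CO[C@H]3C[C@@H](N=C=S)C3)c(F)c2)cc1F` gives 227 nM.

Compound 3 thus carries the highest number of the three; the values of compound 2 and of compound 1 both lie lower, each by a gap beyond the scatter, with compound 1 farthest away.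

Compound 4 `CCOc1ccc(-c2ccc(CO[C@H]3C[C@@H](N=C=S)C3)c(F)c2)cc1F` is not yet measured. It differs from compound 3 in one place: ethoxy in place of isopropyl on an aromatic carbon. Among the measured compounds shown here, no measured pair in the set shows this exchange directly, so its size is open. Given that compound 2, which carries a methoxy on its outer ring, gives 20 nM, a modest step toward a lower number is expected, a 2.3-fold lower number from compound 3 to compound 4 (0.36 log units; beyond the scatter), roughly at the edge of the scatter. The estimate for compound 4 in this assay is 100 nM, with a range from 35 nM to 300 nM.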

Compound 4, half-maximal inhibitory concentration: 69.2 nM
Beside the measured number, compound 4's estimate is 1.4-fold (0.16 log units) above it, and the stated range covers the measured number.
By their numbers in this assay, from the lowest: compound 1; then compound 2; then compound 4; then compound 3.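

At this position, on an aromatic carbon ortho to a fluoro group and para to a large group, the number in this assay responds to the identity of the group: ethoxy in place of isopropyl gives a step beyond the scatter (a 3.3-fold lower number from compound 3 to compound 4 (0.52 log units; beyond the scatter)). The two groups have the same count of heavy atoms, yet only ethoxy brings a hydrogen-bond acceptor. No evidence bears on the reason for this step.

As far as these compounds go, whether a propoxy or an amine here would lower the number further remains open. From the compounds shown here alone, it is also open whether the step carries over to other cores.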